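The source may report more compounds than this note shows. Statements on the series, on what has been measured and on what is new or still open speak of the compounds shown alone.

Two compounds share one core and differ only in a single group on an aromatic carbon. In a functional assay, read by spectrophotometry, with a stated time of 15 min, tested at 100 ug/mL (a lower number here means a weaker effect, a higher number a stronger effect of the compound at the concentration tested), compound 2 `COc1ccc(-c2csc(N/N=C/c3ccc(Cl)cc3Cl)n2)cc1` gives 87.5%, and compound 1 `Cc1ccc(-c2csc(N/N=C/c3ccc(Cl)cc3Cl)n2)cc1` gives 85.3%; the step of a number 2.2 percentage points higher from compound 1 to compound 2 (within the scatter) lies within the scatter, so on these two numbers compound 2 cannot be set apart from compound 1. Compound 3 `Clc1ccc(-c2csc(N/N=C/c3ccc(Cl)cc3Cl)n2)cc1` differs from compound 2 by chloro in place of methoxy on an aromatic carbon. Within the data shown here, the only measured step that bears on this change is the one from compound 1 to compound 2, also a replacement of a group on an aromatic carbon, and it stayed within the scatter. Compound 3 is therefore expected to show no step beyond the scatter, a number 2.5 percentage points lower from compound 2 to compound 3 (within the scatter). In this assay compound 3 is estimated at 85%, within a range from 72% to 95%.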

Compound 3, a percentage reported as inhibition, at one concentration (the size of the read-out at that concentration, not a potency): 84.4%
Compound 3: the middle estimate sits 0.6 percentage points above what was measured; measured number inside the range.
By their numbers in this assay, from the lowest: compounds 3, 1 and 2 (each within the scatter of the next).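

In this assay chloro now stands with methyl and methoxy on this aromatic carbon, para to a large group, and the change to chloro gives a number 3.1 percentage points lower from compound 2 to compound 3 (within the scatter) when methoxy leaves and a number 0.9 percentage points lower from compound 1 to compound 3 (within the scatter) when methyl leaves. The hydrogen-bond acceptor counted for methoxy can therefore go without a step beyond the scatter, and a halogen fits the same place without one as well, so all three groups remain indistinguishable here. No measurement at hand explains why these replacements leave the read-out within the scatter.

Going by these compounds, whether an amine, a carboxylic acid or a longer chain at this place would give a step beyond the scatter remains open. On these data alone, the rest of the shared core is the same in all three compounds, so the effect of a change elsewhere also remains unknown.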